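Bromo for Chloro on a Coumarin-Isatin Hybrid

The source may hold more compounds than are shown below. What is called first, only, known or untested is meant among the compounds shown, and "the series" means these compounds.

Compound 3 `O=C1C(=O)N(CCCCn2cc(COc3cc(=O)oc4ccccc34)nn2)c2ccc(Cl)cc21` stands highest of the three measured compounds in a functional assay on HCT-116 cells (Homo sapiens) for inhibition, read by sulforhodamine B assay, with a stated time of 48 h, tested at 50 uM (on this read-out lower numbers stand for less inhibition of growth and higher numbers for more inhibition of growth at the one concentration tested), giving 62%. Its closest companion is compound 2 `O=C1C(=O)N(CCCCCn2cc(COc3cc(=O)oc4ccccc34)nn2)c2ccc(Br)cc21`, which gives 43%, and furthest away lies compound 1 `COc1ccc2c(c1)C(=O)C(=O)N2CCCCCn1cc(COc2cc(=O)oc3ccccc23)nn1`, which gives 25%. Compound 4 `O=C1C(=O)N(CCCCn2cc(COc3cc(=O)oc4ccccc34)nn2)c2ccc(Br)cc21` has not yet been tested; it differs from compound 3 in one place: bromo in place of chloro on an aromatic carbon.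

Among the compounds with values here, no measured pair shows exactly this swap. Within the data shown here, the one step that touches the same aromatic carbon is a number 18 percentage points higher from compound 1 to compound 2 (beyond the scatter), but that exchanged a methoxy for a bromo, not a chloro for a bromo. Compound 2 and compound 3 carry different halogens and also differ in chain length, so their values alone cannot separate the two effects. Among the measured compounds shown here, with no direct precedent, a change of one halogen for a neighbouring one is expected to move this assay little, and the estimated step of a number 2 percentage points lower from compound 3 to compound 4 (within the scatter) is expected to lie within the scatter. Compound 4 is therefore estimated at 60%, within a range of 45% to 75%.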

Compound 4, percent growth inhibition at one concentration: 59%
Estimate against measurement, compound 4: 1 percentage points above; measured number inside the range.
By their numbers in this assay, from the lowest: compound 1; then compound 2; then compounds 4 and 3 (each within the scatter of the next).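

In this assay, bromo in place of chloro on this aromatic carbon gives a number 3 percentage points lower from compound 3 to compound 4 (within the scatter), so these two halogens cannot be told apart at this position, whereas the earlier exchange of methoxy for bromo gave a number 18 percentage points higher from compound 1 to compound 2 (beyond the scatter). Within the data shown here, compound 4 also supplies a cleaner comparison than the earlier compounds allowed: it shares its bromo with compound 2 and differs from it only in chain length, with compound 2 giving 43% and compound 4 giving 59%. No measurement shown here bears on the reason for the halogen result.

On these data alone, it remains open whether an amine or a carboxylic acid on this aromatic carbon would read like the halogens or like methoxy. The compounds shown also leave open how a chain longer than that of compound 2 would read.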